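Bromo to Methyl on the Aryl Urea Sulfonamides

This account rests on a few compounds, and the source may have more. Where it says the series, first, only, none or still open, it means among the compounds named here.

Measured so far:
compound 1, `Cc1cccc2cc(S(=O)(=O)NC(=O)Nc3ccc(Cl)cc3)oc12`, 21%;
compound 2, `O=C(Nc1ccc(Cl)cc1)NS(=O)(=O)c1cc2cccc(Br)c2o1`, 18%;
compound 3, `O=C(Nc1ccc(Br)cc1)NS(=O)(=O)c1cc2ccccc2o1`, 48%.

All three were tested in a functional assay on the whole organism (Mus musculus) for inhibition, at a dose of 150 mg/kg by the oral route; a lower number here means less inhibition, a higher number more inhibition at the dose given (going by the name of the read-out). Compound 3 stands highest there, beyond the scatter from both compound 1 and compound 2. How the core of compound 3 differs from that of compound 2 is not broken down here. Between compound 2 and compound 1 the change is methyl in place of bromo on an aromatic carbon, and it made a step of a number 3 percentage points higher from compound 2 to compound 1 (within the scatter). Compound 4, `Cc1ccc(NC(=O)NS(=O)(=O)c2cc3ccccc3o2)cc1`, is not yet measured; it differs from compound 3 by methyl in place of bromo on an aromatic carbon. This is the same kind of change, but the place differs: in compound 1 it sits ortho and meta to a fused ring, in compound 4 para to a large group on a carbon-only ring. Because the earlier step of a number 3 percentage points higher from compound 2 to compound 1 (within the scatter) was small, compound 4 is expected to stay close to compound 3, an estimated step of a number 2 percentage points higher from compound 3 to compound 4 (within the scatter). Compound 4 is therefore estimated at 50%, between 30% and 70%.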

Compound 4, a percentage reported as inhibition, in the whole organism at one dose (the size of the read-out at that dose, not a potency): 11%
Estimate against measurement, compound 4: 39 percentage points above, outside the stated range (below it).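

In this assay, methyl in place of bromo on the six-membered carbon ring gave a clear drop, a number 37 percentage points lower from compound 3 to compound 4 (beyond the scatter). The same kind of change therefore did not carry over with the same result from one core to another: the same change on two cores in this assay, a number 3 percentage points higher (within the scatter) from compound 2 to compound 1 and a number 37 percentage points lower (beyond the scatter) from compound 3 to compound 4, 40 percentage points apart, beyond the scatter of two such steps This does not show why the two steps differ, since the two pairs differ in both the core and the place of the change, and two pairs cannot separate those factors.

The compounds shown leave open how another group in that place on the core of compound 3, such as methoxy or an amine, would fare. They also leave open what this change would do on a further core.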